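Benzamide aryl variation on the shared core: compound 4

The compounds below may be only part of what the source reports. "The series", "measured", "known", "first", "only" and "open" are said of these compounds alone.

Three analogues that differ only in the aryl group of the benzamide have been measured in an in vitro functional assay on CHO/Galpha16 cells for antagonist activity at C-C chemokine receptor type 8 (Homo sapiens), read by FLIPR; on this read-out lower numbers stand for stronger inhibition and higher numbers for weaker inhibition. Compound 1 `CCCC(=O)N1CCC(NS(=O)(=O)c2ccc(NC(=O)c3cccc(C)c3)c3ccccc23)CC1` gives 5.1 nM in this assay. Compound 2 `CCCC(=O)N1CCC(NS(=O)(=O)c2ccc(NC(=O)c3ccc(F)cc3)c3ccccc23)CC1` gives 59.5 nM in this assay, and compound 3 `CCCC(=O)N1CCC(NS(=O)(=O)c2ccc(NC(=O)c3ccc(CC)cc3)c3ccccc23)CC1` gives 10.8 nM in this assay. Compound 3 thus stands second highest of the three numbers: the smaller gap is a 2.1-fold higher number from compound 1 to compound 3 (0.33 log units; beyond the scatter), the larger gap is a 5.5-fold lower number from compound 2 to compound 3 (0.74 log units; beyond the scatter).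

Compound 4 `CCCC(=O)N1CCC(NS(=O)(=O)c2ccc(NC(=O)c3ccc(C(C)(C)C)cc3)c3ccccc23)CC1` is the next step from compound 3: tert-butyl in place of ethyl on an aromatic carbon. For the measured compounds named here, no measured step exchanges one alkyl group for a larger alkyl group on this ring, so there is no direct precedent. The step that bears most closely on it is a 5.5-fold lower number from compound 2 to compound 3 (0.74 log units; beyond the scatter), where a carbon substituent at the same place gave the lower number; the step of a 2.1-fold higher number from compound 1 to compound 3 (0.33 log units; beyond the scatter) shows that variation of the aryl group is tolerated at modest cost. On this basis the expected step in this assay is a 1.1-fold higher number from compound 3 to compound 4 (0.05 log units; within the scatter), small and without a clear direction, likely within or near the scatter. Compound 4 is therefore estimated at 12 nM in this assay, with a range from 4 nM to 40 nM.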

Compound 4, half-maximal inhibitory concentration: 6.9 nM
Estimate against measurement, compound 4: 1.7-fold (0.24 log units) above; the measured number falls inside the stated range.
By their numbers in this assay, from the lowest: compounds 1, 4 and 3 (each within the scatter of the next, the first and the last beyond it); then compound 2.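

In this assay, for the compounds shown here, the exchange of ethyl for tert-butyl is the only comparison here of two alkyl groups at this place, and the step, a 1.6-fold lower number from compound 3 to compound 4 (0.19 log units; within the scatter), shows no readable difference, so the larger group is tolerated on this ring. Fluoro stays apart from tert-butyl at the same place, with an 8.6-fold lower number from compound 2 to compound 4 (0.94 log units; beyond the scatter), so on these compounds both alkyl groups, ethyl in compound 3 and tert-butyl in compound 4, stand apart from the fluoro of compound 2. The 4-(tert-butyl)phenyl group also cannot be told from the 3-methylphenyl group, with a 1.4-fold higher number from compound 1 to compound 4 (0.13 log units; within the scatter), while the 4-ethylphenyl group of compound 3 stands just beyond the scatter from compound 1; nothing at hand explains these numbers.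

The compounds shown do not separate the effect of the substituent's place on the ring from that of the substituent itself, as no single group appears at both places. They also leave open how an amine or a carboxylic acid at this place would compare with the alkyl groups, and whether a longer chain such as n-butyl would read like ethyl and tert-butyl.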